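The source may hold more compounds than are shown below. What is called first, only, known or untested is meant among the compounds shown, and "the series" means these compounds.

Measured compounds:
Compound 1, `Oc1ccccc1/C=N/c1ccc(F)c(Cl)c1`: 100000 nM
Compound 2, `NC(=S)N/N=C/c1ccccc1Cl`: 98000 nM

Both numbers come from a functional assay on CCRF-CEM cells (Homo sapiens) for cytotoxicity; a higher number here means a weaker inhibitor, a lower number a stronger inhibitor. In this assay compound 1 gives 100000 nM, and compound 2 gives 98000 nM. The two values lie within the usual scatter of each other, so the data do not separate them; both compounds kill these cells only at very high concentrations, which makes each a weak inhibitor.

Compound 3, `NC(=S)N/N=C/c1ccccc1F`, keeps the core of compound 2 and changes one position: fluoro in place of chloro on an aromatic carbon. For the measured compounds named here, no pair of measured compounds shows what this exchange does here, so nothing beyond the value of compound 2 itself can guide the expectation. Swapping one halogen atom for another at the same aromatic carbon is a small change, and compound 2 already sits at the weak end of this assay. The step from compound 2 to compound 3 is therefore expected to be a 1.0-fold higher number from compound 2 to compound 3 (0.01 log units; within the scatter), nothing beyond the scatter. For compound 3 the estimated value in this assay is 100000 nM, with a likely range from 40000 nM to 250000 nM.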

Compound 3, half-maximal inhibitory concentration: 166000 nM
Estimate against measurement, compound 3: 1.7-fold (0.22 log units) below; the measured number falls inside the stated range.
By their numbers in this assay, from the lowest: compounds 2, 1 and 3 (each within the scatter of the next).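

In this assay the exchange of fluoro for chloro on an aromatic carbon gives a 1.7-fold higher number from compound 2 to compound 3 (0.23 log units; within the scatter) and so does not separate the two compounds. For the compounds shown here, this is the only single-place comparison available so far, and it shows that, at this position on the core of compound 2, the two halogens cannot be told apart by their numbers, which both stay at the weak end of the assay. No measurement is available that bears on this result.

The compounds shown leave open whether a group of a different kind at this position, such as an amine, a methoxy group or a carboxylic acid, would move the number beyond the scatter. They also leave open whether the same exchange on the core of compound 1 would read the same way.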